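This account rests on a few compounds, and the source may have more. Where it says the series, first, only, none or still open, it means among the compounds named here.

Measured so far in a functional assay on NCI-H460 cells (Homo sapiens) for inhibition, with a stated time of 72 h; a lower number here means a stronger inhibitor, a higher number a weaker inhibitor:
compound 1 `COc1ccc(S(=O)(=O)N2CCc3cccc(-c4ccc(N(C)C)cc4)c32)cc1`: 556 nM
compound 2 `COc1ccc(-c2cccc3c2N(S(=O)(=O)c2ccc(OC)cc2)CC3)cc1`: 302 nM
compound 3 `COc1ccc(S(=O)(=O)N2CCc3cccc(-c4cccnc4)c32)cc1`: 89.6 nM

Compound 3 has the lowest number of the three, and both steps reaching it lie beyond the scatter: a 3.4-fold lower number from compound 2 to compound 3 (0.53 log units; beyond the scatter) and a 6.2-fold lower number from compound 1 to compound 3 (0.79 log units; beyond the scatter).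

The next compound is compound 4 `COc1ccc(S(=O)(=O)N2CCc3cccc(-c4ccccc4)c32)cc1`. The change is phenyl in place of pyridin-3-yl on an aromatic carbon.

The two steps above bear on it most directly, since each puts pyridin-3-yl in place of a 4-substituted phenyl, and both were modest. A further step, a 1.8-fold lower number from compound 1 to compound 2 (0.27 log units; within the scatter), shows no separation between the 4-methoxyphenyl and 4-(dimethylamino)phenyl compounds. For the measured compounds named here, no compound with plain phenyl has been measured, so these data cannot say how much of the gain remains without the 4-substituent. In this assay, a small rise is therefore expected, no larger than the measured modest steps. The expected step is a 1.7-fold higher number from compound 3 to compound 4 (0.22 log units; within the scatter). For compound 4 the estimated value is 150 nM, with an expected range of 60 nM to 380 nM.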

Compound 4, half-maximal inhibitory concentration: 213 nM
Compound 4: the middle estimate sits 1.4-fold (0.15 log units) below what was measured, within the range that was stated.
By their numbers in this assay, from the lowest: compound 3; then compounds 4, 2 and 1 (each within the scatter of the next, the first and the last beyond it).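

In this assay, the gain with pyridin-3-yl also holds against plain phenyl (a 2.4-fold higher number from compound 3 to compound 4 (0.38 log units; beyond the scatter)), so it does not depend on comparison with a 4-substituted phenyl alone. Taking off the substituent gives different readings: the loss of methoxy stays within the scatter (a 1.4-fold lower number from compound 2 to compound 4 (0.15 log units; within the scatter)), while the loss of dimethylamino is a modest step beyond it (a 2.6-fold lower number from compound 1 to compound 4 (0.42 log units; beyond the scatter)). No measured evidence is available to explain these steps.

On these data alone, it remains open whether the gain depends on where the ring nitrogen sits, which pyridin-2-yl and pyridin-4-yl would test. As far as these compounds go, it is also open how this position responds to a carboxylic acid or an aminomethyl group on the phenyl.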